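Hydroxy in place of trifluoromethyl on compound 3

This account rests on a few compounds, and the source may have more. Where it says the series, first, only, none or still open, it means among the compounds named here.

Compound 1 `Oc1ccc(-c2ccc(-c3ccc(-c4nc5ccccc5[nH]4)cc3)cc2)cc1` gives 30500 nM
Compound 2 `Oc1cccc2[nH]c(-c3ccc(-c4ccc(-c5ccc(F)cc5)cc4)cc3)nc12` gives 3010 nM
Compound 3 `Oc1cccc2[nH]c(-c3ccc(-c4ccc(-c5ccc(C(F)(F)F)cc5)cc4)cc3)nc12` gives 2310 nM

In a functional assay on MCF7 cells (Homo sapiens) for inhibition, read by sulforhodamine B assay (a lower number here means a stronger inhibitor of growth, a higher number a weaker inhibitor of growth), compound 3 and compound 2 lie within the scatter of each other at the low end of the numbers, while compound 1 stands clearly higher. Compound 4 `Oc1ccc(-c2ccc(-c3ccc(-c4nc5c(O)cccc5[nH]4)cc3)cc2)cc1` has not yet been measured. It differs from compound 3 by hydroxy in place of trifluoromethyl on an aromatic carbon, para to a large group, and the change is hydroxy in place of trifluoromethyl on an aromatic carbon. For the measured compounds named here, the only measured step at this place is a 1.3-fold lower number from compound 2 to compound 3 (0.11 log units; within the scatter), which stays within the scatter, but it does not involve hydroxy. Compound 1 also carries 4-hydroxyphenyl, though it is no exact match for compound 4. The value of compound 1 of 30500 nM makes a move toward a higher number the more likely direction, so a small step upward is expected in this assay, with wide uncertainty. The expected change is a 2.2-fold higher number from compound 3 to compound 4 (0.34 log units; beyond the scatter). For compound 4 the estimated value is 5000 nM, with an expected range from 1300 nM to 19000 nM.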

Compound 4, concentration for 50% growth inhibition: 190 nM
For compound 4 the middle estimate is 26-fold (1.42 log units) above the measured one; measured number outside the range, below it.
By their numbers in this assay, from the lowest: compound 4; then compounds 3 and 2 (each within the scatter of the next); then compound 1.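

In this assay, this position, para to a large group, turns out to matter far more than the earlier exchange of fluoro and trifluoromethyl suggested, since that step stayed within the scatter. Hydroxy in place of trifluoromethyl gives a 12-fold lower number from compound 3 to compound 4 (1.08 log units; beyond the scatter), and hydroxy in place of fluoro gives a 16-fold lower number from compound 2 to compound 4 (1.20 log units; beyond the scatter). The 4-hydroxyphenyl alone does not account for the low number, as hydroxy in place of hydrogen on an aromatic carbon of the core gives a 160-fold lower number from compound 1 to compound 4 (2.21 log units; beyond the scatter), so among these compounds the low number appears only where both hydroxy groups are present.

On these data alone, whether a methoxy, an amine or a carboxylic acid at this position would keep the low number remains open. No data shown here explain the size of these steps.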